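Swapping cyclopropyl for isobutoxy on the thiazole-side carbonyl

The compounds below may be only part of what the source reports. "The series", "measured", "known", "first", "only" and "open" are said of these compounds alone.

Measured compounds:
compound 1 `O=C(Nc1ccc2nc(NC(=O)C3CCCCC3)sc2c1)c1ccccc1C(F)(F)F`: 0.024 ug/mL
compound 2 `CCCC(C)C(=O)Nc1ccc2nc(NC(=O)C3CCCCC3)sc2c1`: 0.14 ug/mL
compound 3 `O=C(Nc1ccc2nc(NC(=O)C3CC3)sc2c1)c1c(Cl)cccc1Cl`: 0.013 ug/mL

These three compounds share one core and were tested in a functional assay on WI-38 VA13 cells (Homo sapiens) for cytotoxicity; on this read-out higher numbers stand for an effect only at larger amounts of compound and lower numbers for an effect already at smaller amounts. Compound 3 gives the lowest of the three numbers, at 0.013 ug/mL. Compound 1, with 0.024 ug/mL, sits within the scatter of compound 3, so no difference between the two can be claimed. Compound 2, at 0.14 ug/mL, lies beyond the scatter from compound 3.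

Among the measured compounds shown here, the only measured step, a 5.8-fold higher number from compound 1 to compound 2 (0.77 log units; beyond the scatter), changes the group on the carbonyl carbon that carries the aryl amide, not the carbonyl on the other side of the core.

The new compound 4 `CC(C)COC(=O)Nc1nc2ccc(NC(=O)c3c(Cl)cccc3Cl)cc2s1` differs from compound 3 on that other side: isobutoxy in place of cyclopropyl on a carbonyl carbon. For the measured compounds named here, no measured step touches this position, so there is nothing to set a direction or size for the change with confidence.

In the absence of a relevant step, compound 4 is expected to remain close to compound 3, with an estimated step of a 2.3-fold higher number from compound 3 to compound 4 (0.36 log units; beyond the scatter) in this assay. The estimate for compound 4 is 0.03 ug/mL, within a range of 0.008 ug/mL to 0.12 ug/mL.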

Compound 4, half-maximal effective concentration: 0.0035 ug/mL
The estimate for compound 4 lay 8.6-fold (0.93 log units) above the measured number, and the stated range ends above it.
By their numbers in this assay, from the lowest: compound 4; then compounds 3 and 1 (each within the scatter of the next); then compound 2.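

Among the compounds shown here, the carbonyl carbon whose other neighbour is the amide-type nitrogen had no measured step among the earlier compounds, so nothing showed whether a change there would matter. In this assay the swap of cyclopropyl for isobutoxy gives a 3.7-fold lower number from compound 3 to compound 4 (0.57 log units; beyond the scatter) and shows that this position does affect the read-out, with the change beyond the usual scatter and towards an effect at smaller amounts of compound. It also shows that the ring on this carbonyl is not needed for a low number, since an open isobutoxy group with more heavy atoms takes its place and the number still falls, although nothing shown here explains that fall.

This one step cannot separate the loss of the ring from the gain of the oxygen, and a longer carbon chain or an amine on the same carbonyl carbon would help to tell the two apart. Going by these compounds, it also remains open whether isobutoxy would give a similar step in compound 1 or compound 2, which differ from compound 3 in other places too.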